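Amide nitrogen substituents: from compound 3 to compound 4

The source may hold more compounds than are shown below. What is called first, only, known or untested is meant among the compounds shown, and "the series" means these compounds.

Compound 3 `COc1ccc(NC(=O)c2nc(-c3cc(OC)c(OC)c(OC)c3)n(-c3ccc(OC)cc3)n2)cc1` carries a 4-methoxyphenyl on the amide nitrogen. In a functional assay on the whole organism for inhibition, with Rattus norvegicus as the target, read by paw edema, with stated times of 30 min and 1 h, at a dose of 0.28 mmol/kg by the oral route (on this read-out lower numbers stand for less inhibition and higher numbers for more inhibition at the one dose given (going by the name of the read-out)), compound 3 gives 39%, the smallest of the three numbers at hand, though it is not separated from compound 1 `COc1ccc(-n2nc(C(N)=O)nc2-c2cc(OC)c(OC)c(OC)c2)cc1`, which gives 40%, as a number 1 percentage points lower from compound 1 to compound 3 (within the scatter) shows. Compound 2 `CCNC(=O)c1nc(-c2cc(OC)c(OC)c(OC)c2)n(-c2ccc(OC)cc2)n1`, with ethyl on that nitrogen, gives 60%; the step of a number 21 percentage points lower from compound 2 to compound 3 (beyond the scatter) is beyond the scatter, as is a number 20 percentage points higher from compound 1 to compound 2 (beyond the scatter).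

Compound 4 `COc1ccc(-n2nc(C(=O)Nc3ccccc3OC)nc2-c2cc(OC)c(OC)c(OC)c2)cc1` differs from compound 3 at the amide nitrogen alone: 2-methoxyphenyl in place of 4-methoxyphenyl on an amide-type nitrogen. The measured steps all exchange hydrogen, ethyl or 4-methoxyphenyl at this nitrogen and show that it can shift the read-out by about the size of a number 21 percentage points lower from compound 2 to compound 3 (beyond the scatter). None of them exchanges one methoxyphenyl for another, so no direction can be read for the present change. Compound 4 is therefore expected to show a number 1 percentage points higher from compound 3 to compound 4 (within the scatter). Compound 4 is estimated at 40%, in a range from 25% to 58%.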

Compound 4, a percentage reported as inhibition, in the whole organism at one dose (the size of the read-out at that dose, not a potency): 52%
For compound 4 the middle estimate is 12 percentage points below the measured one; the range from low to high includes it.
By their numbers in this assay, from the lowest: compounds 3 and 1 (each within the scatter of the next); then compounds 4 and 2 (each within the scatter of the next).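

The place of the methoxy group on the aryl ring counts at this position: in this assay, 2-methoxyphenyl in place of 4-methoxyphenyl on the amide-type nitrogen gives a number 13 percentage points higher from compound 3 to compound 4 (beyond the scatter), although the two groups have the same atoms. An aryl group on this nitrogen therefore need not leave the read-out at the level of the primary amide, as the exchange of hydrogen for 2-methoxyphenyl gives a number 12 percentage points higher from compound 1 to compound 4 (beyond the scatter), while the exchange of ethyl for 2-methoxyphenyl gives a number 8 percentage points lower from compound 2 to compound 4 (within the scatter). No measurement at hand accounts for the difference between the two methoxyphenyl groups.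

The compounds shown leave open how an unsubstituted phenyl or a longer chain such as butyl on this nitrogen would read. They also leave open how a carboxylic acid in place of the amide would compare.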